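Adding a methyl to compound 2 at the assay limit

A few compounds are considered here, and "the series" means these few. Any claim that something is new, unique, unknown or untested is made for them only; others in the source may bear on it.

Compound 1 `CC1CCC(=O)N1CC#CCN(C)C`: > 100 mg/kg
Compound 2 `CC(=O)NCC#CCn1ccnc1`: > 100 mg/kg

Both compounds were tested in a functional assay on the whole organism for antagonist activity, with Mus musculus as the target; a lower number here means that less compound is needed, a higher number that more compound is needed for the effect. Compound 2 stands at the limit of > 100 mg/kg in this assay, at which 2 of the 2 values shown sit, and this is a limit, not a number. Compound 3 `CC(=O)NCC#CCn1cncc1C` is not yet measured. It differs from compound 2 by one change, (methyl in place of hydrogen on an aromatic carbon), with methyl in place of hydrogen on an aromatic carbon. Going by the values given here, no measured step shows the size of such a change, so no step beyond the scatter is expected in this assay, in either direction. The expected step is a step that the limit leaves unreadable from compound 2 to compound 3. Compound 3 is estimated at 150 mg/kg, with an expected range from 50 mg/kg to 400 mg/kg.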

Compound 3, dose for half-maximal effect: > 100 mg/kg
Compound 3: a limit, no number; the forecaster's own chance of this, stated with the estimate: 75%; the middle value lies beyond the limit too.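

In this assay compound 3 gives > 100 mg/kg, which is a limit and not a number. Going by these compounds alone, no step from compound 2 to compound 3 can be read: the limit of > 100 mg/kg in this assay, at which 3 of the 3 values shown sit. The compounds shown leave open whether methyl in place of hydrogen changes the dose at all.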